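The source may report more compounds than this note shows. Statements on the series, on what has been measured and on what is new or still open speak of the compounds shown alone.

- Compound 1 `O=C(NO)c1ccc(/C=C/c2ccnc(-c3cccc(O)c3)c2)cc1`: 2100 nM
- Compound 2 `O=C(NO)c1ccc(/C=C/c2ccnc(-c3cccnc3)c2)cc1`: 4550 nM

In a functional assay on MGC-803 cells (Homo sapiens) for antiproliferative activity, read by CellTiter-Glo, with a stated time of 72 h (a higher number here means a weaker inhibitor, a lower number a stronger inhibitor), compound 2 has the higher of the two numbers at 4550 nM, which makes it the weaker inhibitor of the pair. The next compound, compound 3 `COc1ccc(-c2cc(/C=C/c3ccc(C(=O)NO)cc3)ccn2)cc1`, differs from it as follows: 4-methoxyphenyl in place of pyridin-3-yl on an aromatic carbon. In words, 4-methoxyphenyl stands in place of pyridin-3-yl on an aromatic carbon. Among the compounds with values here, only one measured step bears on this change: a 2.2-fold higher number from compound 1 to compound 2 (0.34 log units; beyond the scatter). This modest step came with pyridin-3-yl in place of 3-hydroxyphenyl. With compound 1 at 2100 nM, the ring of carbon only has so far given the lower number, so a modest move to a lower number is expected in this assay. From the compounds shown here alone, this rests on a single pair, and 4-methoxyphenyl itself is untested. The expected change is a 1.6-fold lower number from compound 2 to compound 3 (0.21 log units; within the scatter). For compound 3 the estimated value is 2800 nM, with an expected range of 1100 nM to 7000 nM.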

Compound 3, half-maximal inhibitory concentration: 3510 nM
Compound 3: middle estimate off by 1.3-fold (0.10 log units), on the low side; measured number inside the range.
By their numbers in this assay, from the lowest: compounds 1, 3 and 2 (each within the scatter of the next, the first and the last beyond it).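

In this assay, the ring of carbon only at this position, next to the ring nitrogen, does not set itself apart from pyridin-3-yl: the change to 4-methoxyphenyl gives a 1.3-fold lower number from compound 2 to compound 3 (0.11 log units; within the scatter). Nor can it be told apart from the 3-hydroxyphenyl group, with a 1.7-fold higher number from compound 1 to compound 3 (0.22 log units; within the scatter). Within the data shown here, compound 3 therefore sits within the scatter of both neighbours, so the single earlier step does not show that a ring of carbon only is enough to give the lower number, and nothing available explains these results.

From the compounds shown here alone, it remains open whether 3-methoxyphenyl would separate the effect of the group's place on the ring from that of hydroxyl versus methoxy. All three compounds carry a six-membered aromatic ring here, so how an amine or a carboxylic acid on that ring would read is also unknown.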